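Swapping the aryl amide in a quinazoline-free core series

A few compounds are considered here, and "the series" means these few. Any claim that something is new, unique, unknown or untested is made for them only; others in the source may bear on it.

Compound 1 `COc1cc2ncnc(NNC(=S)NC(=O)c3ccc(C(F)(F)F)cc3)c2cc1OC` gives 16800 nM in a functional assay on MCF7 cells (Homo sapiens) for cytotoxicity, read by MTT assay, with a stated time of 72 h (a higher number here means a weaker inhibitor, a lower number a stronger inhibitor), the highest of the three numbers measured. Its nearest neighbour is compound 3 `COc1cc2ncnc(NNC(=S)NC(=O)c3ccccc3)c2cc1OC`, which gives 6990 nM; the step of a 2.4-fold lower number from compound 1 to compound 3 (0.38 log units; beyond the scatter) comes from hydrogen in place of trifluoromethyl on an aromatic carbon. Furthest away is compound 2 `O=C(NC(=S)NNc1ncnc2ccccc12)c1cccc(Cl)c1`, which carries a different core and gives 3540 nM.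

Compound 4 `COc1cc2ncnc(NNC(=S)NC(=O)c3cccc(Cl)c3)c2cc1OC` keeps the core of compound 1 and differs from it as follows: 3-chlorophenyl in place of 4-(trifluoromethyl)phenyl on a carbonyl carbon. Going by the values given here, the only measured step that bears directly on this is that from compound 1 to compound 3, which removes the trifluoromethyl and lowers the number modestly. Among the compounds with values here, compound 2 shows that a 3-chlorophenyl on this carbonyl carbon can sit with a low number, though on another core, so no step to it can be counted. The expected step is therefore a 3.1-fold lower number from compound 1 to compound 4 (0.48 log units; beyond the scatter), in the direction of a lower number. Compound 4 is estimated at 5500 nM, with a range from 2000 nM to 15000 nM.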

Compound 4, half-maximal inhibitory concentration: 11500 nM
Estimate against measurement, compound 4: 2.1-fold (0.32 log units) below, and the stated range covers the measured number.
By their numbers in this assay, from the lowest: compounds 2, 3, 4 and 1 (each within the scatter of the next, the first and the last beyond it).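

On the shared core, the change on the carbonyl carbon gives a step (in this assay: a 1.5-fold lower number from compound 1 to compound 4 (0.16 log units; within the scatter)), and adding chloro to the phenyl of compound 3 gives another (a 1.6-fold higher number from compound 3 to compound 4 (0.22 log units; within the scatter)). Compound 4 therefore cannot be told apart from either compound 1 or compound 3, although those two stand apart from each other by a step beyond the scatter, so 3-chlorophenyl on this carbonyl carbon does not separate from either of the other two aryl groups. No measured finding is available to explain this result.

On these data alone, it remains open whether an amine or a carboxylic acid in place of the chloro would give a step beyond the scatter. As far as these compounds go, it is also open how compound 2 would compare with a partner that has hydrogen in place of chloro on its own core.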